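Reversing an Amide on a Saturated Ring Carbon

The compounds below may be only part of what the source reports. "The series", "measured", "known", "first", "only" and "open" are said of these compounds alone.

Three compounds share one core and differ only in the group on a saturated ring carbon. In an assay on isolated protein for inhibition of Substance-P receptor (Cavia porcellus), tested at 1 ug/mL (a lower number here means less inhibition, a higher number more inhibition at the concentration tested (going by the name of the read-out)), compound 1 `COc1cc(C(=O)N2CO[C@](CCN3CCC(n4c(O)nc5ccccc54)CC3)(c3ccc(Cl)c(Cl)c3)C2)cc(OC)c1OC` gives 100%, compound 2 `COc1cc(C(=O)N2CO[C@](CCN3CCC(C(=O)c4ccc(Cl)cc4)CC3)(c3ccc(Cl)c(Cl)c3)C2)cc(OC)c1OC` gives 97%, and compound 3 `COc1cc(C(=O)N2CO[C@](CCN3CCC(NC(=O)c4ccccc4)CC3)(c3ccc(Cl)c(Cl)c3)C2)cc(OC)c1OC` gives 89%, the lowest of the three numbers. The step of a number 11 percentage points lower from compound 1 to compound 3 (beyond the scatter) lies beyond the scatter, whereas the steps of a number 8 percentage points lower from compound 2 to compound 3 (within the scatter) and a number 3 percentage points lower from compound 1 to compound 2 (within the scatter) do not. Compound 4 `COc1cc(C(=O)N2CO[C@](CCN3CCC(C(=O)Nc4ccccc4)CC3)(c3ccc(Cl)c(Cl)c3)C2)cc(OC)c1OC` differs from compound 3 by phenylcarbamoyl in place of benzamido on a saturated ring carbon. Among the compounds with values here, no measured step tests this reversal of the amide, but every group tried at this position has kept inhibition high, so the expected step of a number 1 percentage points lower from compound 3 to compound 4 (within the scatter) is small and likely within the scatter. Compound 4 is therefore estimated at 88%, between 74% and 98%.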

Compound 4, a percentage reported as inhibition, at one concentration (the size of the read-out at that concentration, not a potency): 44%
Compound 4: the middle estimate sits 44 percentage points above what was measured, and the stated range ends above it.
By their numbers in this assay, from the lowest: compound 4; then compounds 3, 2 and 1 (each within the scatter of the next, the first and the last beyond it).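

At this saturated ring carbon the direction of the amide matters: phenylcarbamoyl in place of benzamido, with the same atoms joined differently, gives a number 45 percentage points lower from compound 3 to compound 4 (beyond the scatter) in this assay. Within the data shown here, the position is not as indifferent to its group as the earlier compounds suggested, and the other two comparisons show the same fall, with a number 53 percentage points lower from compound 2 to compound 4 (beyond the scatter) and a number 56 percentage points lower from compound 1 to compound 4 (beyond the scatter).

Going by these compounds, whether a methyl group on the amide nitrogen, or a longer chain between the carbonyl and the phenyl ring, would bring inhibition back stays open. Nothing available says why the reversed amide falls so far.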